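The compounds below may be only part of what the source reports. "The series", "measured", "known", "first", "only" and "open" are said of these compounds alone.

Measured compounds in an ADME assay on HEK293 cells (Homo sapiens) for cytotoxicity, read by resazurin assay, with a stated time of 48 h; on this read-out higher numbers stand for lower toxicity in this test and lower numbers for higher toxicity in this test:
compound 1, `O=S(=O)(Nc1ccc2oc(-c3ccccc3)nc2c1)c1ccc(Cl)cc1`, 65000 nM
compound 2, `O=S(=O)(Nc1ccc2oc(-c3ccccc3)nc2c1)c1cccc(Cl)c1`, 70000 nM

Among the compounds with values here, compound 2 cannot be set apart from compound 1 on these numbers: the step of a 1.1-fold higher number from compound 1 to compound 2 (0.03 log units; within the scatter) is within the scatter, so the two compounds stand together in this assay, and no other measured compound is at hand for comparison.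

Compound 3, `O=S(=O)(Nc1ccc2oc(-c3ccccc3)nc2c1)c1ccccc1Cl`, keeps the same atoms as compound 2 and differs only in how they are joined: 2-chlorophenyl in place of 3-chlorophenyl on a sulfonyl sulfur.

Within the data shown here, the one measured step that bears on this change is a 1.1-fold higher number from compound 1 to compound 2 (0.03 log units; within the scatter), in which exchanging one chlorophenyl for another on the same sulfonyl sulfur left the cytotoxic concentration unchanged within the scatter. With nothing else to go on, compound 3 is expected to behave alike, with a step of no change at the digits printed from compound 2 to compound 3 (within the scatter) that stays within the scatter.

Compound 3 is therefore estimated at 70000 nM in this assay, with a likely range from 35000 nM to 140000 nM.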

Compound 3, half-maximal cytotoxic concentration: 73000 nM
Compound 3: the middle estimate sits 1.0-fold (0.02 log units) below what was measured, and the stated range covers the measured number.
By their numbers in this assay, from the lowest: compounds 1, 2 and 3 (each within the scatter of the next).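

Placing 2-chlorophenyl on the sulfonyl sulfur gives a 1.0-fold higher number from compound 2 to compound 3 (0.02 log units; within the scatter) and a 1.1-fold higher number from compound 1 to compound 3 (0.05 log units; within the scatter). The earlier pair covered only 3-chlorophenyl and 4-chlorophenyl; now all three chlorophenyl groups stand together in this assay, and on these compounds the choice among them does not separate the numbers. No supporting measurement is at hand that could say why these compounds stand together.

All three compounds carry a chlorophenyl group on the sulfonyl sulfur, so the compounds shown leave open whether the chlorine matters at all, or whether an unsubstituted phenyl, a methoxyphenyl or an aminophenyl there would stand with them. They also leave open whether a carboxylic acid or an amine on the shared core would move the number beyond the scatter.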